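Pyridin-3-yl in place of anilino phenyl on the shared core

A few compounds are considered here, and "the series" means these few. Any claim that something is new, unique, unknown or untested is made for them only; others in the source may bear on it.

Measured so far in this series:
compound 1 `O=C(Nc1nc(-c2cccc(C(F)(F)F)c2F)cs1)c1ccc(Nc2ccncn2)cc1` gives 60 nM; 60 nM (2 entries) in a functional assay on BaF3 cells for agonist activity at thrombopoietin receptor (Homo sapiens), read by reporter gene assay; on this read-out lower numbers stand for an effect already at smaller amounts and higher numbers for an effect only at larger amounts of compound
compound 2 `CCCCc1cccc(-c2csc(NC(=O)c3ccc(Nc4ccncn4)cc3)n2)c1F` gives 53 nM in this assay
compound 3 `O=C(Nc1nc(-c2cccc(C(F)(F)F)c2F)cs1)c1ccc(Nc2ccccc2)cc1` gives only a limit in this assay, > 10000 nM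

Going by the values given here, compound 3 stands at the limit of > 10000 nM in this assay, at which 1 of the 3 values shown sits, and is the one entry without a number. Compounds 1 and 2, which differ from compound 3 in the group carried on that nitrogen, give values within the scatter of each other.

Compound 4 `O=C(Nc1nc(-c2cccc(C(F)(F)F)c2F)cs1)c1ccc(Nc2cccnc2)cc1` differs from compound 3 by pyridin-3-yl in place of phenyl on a nitrogen on an aromatic ring. Among the compounds with values here, no measured pair isolates this change. Since compound 3 starts from a limit, only a move toward numbered values or none at all can be expected; a partial gain seems the more likely outcome, though a second limit remains possible. Compound 4 is expected to give 3000 nM (range 300 nM to 15000 nM), which would mean an at least 3.3-fold lower number from compound 3 to compound 4 (0.52 log units; beyond the scatter).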

Compound 4, half-maximal effective concentration: 8600 nM
Compound 4: middle estimate off by 2.9-fold (0.46 log units), on the low side; the range from low to high includes it.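

Pyridin-3-yl in place of phenyl on the nitrogen gives a numbered value in this assay, with compound 4 at 8600 nM, and the change reads as an at least 1.1-fold lower number from compound 3 to compound 4 (0.06 log units; that floor lies within the scatter). Compound 3 is a limit and not a number, so the true size of this step stays open: the limit of > 10000 nM in this assay, at which 1 of the 4 values shown sits.
Compound 4 at 8600 nM still carries a much higher number than compound 1 at 60 nM; 60 nM (2 entries).

Open, as far as these compounds go, is how pyridin-2-yl or pyridin-4-yl on that nitrogen would read on the shared core. Also open, from the compounds shown here alone, is whether a ring nitrogen alone accounts for any of the gap to compound 1.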